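Phenyl for hydrogen on the coumarin-linked dithiolane amides

The source may report more compounds than this note shows. Statements on the series, on what has been measured and on what is new or still open speak of the compounds shown alone.

This account concerns a small set of compounds sharing a dithiolane-bearing amide tail joined through a triazole to an ether-linked core, tested in a functional assay on PC-12 cells (Rattus norvegicus) for cytotoxicity, read by MTT assay, with stated times of 3 h and 2 h, tested at 0.1 uM; on this read-out higher numbers stand for a stronger effect at the one concentration tested and lower numbers for a weaker effect. Compound 1 `COc1ccc(-c2cc3ccc(OCCCn4cc(CNC(=O)CCCCC5CCSS5)nn4)cc3oc2=O)cc1` gives 42% in this assay. Compound 2 `O=C(CCCCC1CCSS1)NCc1cn(CCCOc2ccc3cc(-c4ccc(Cl)cc4)c(=O)oc3c2)nn1` gives 40.9% in this assay, and the step of a number 1.1 percentage points lower from compound 1 to compound 2 (within the scatter) lies within the scatter. Compound 3 `O=C(CCCCC1CCSS1)NCc1cn(CCCCOc2ccc3ccc(=O)oc3c2)nn1` gives 40.5% in this assay, the lowest of the three numbers, yet its nearest neighbour compound 2 stands only within the scatter above it, and the furthest, compound 1, is also within the scatter of it.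

The next compound, compound 4 `O=C(CCCCC1CCSS1)NCc1cn(CCCCOc2ccc3cc(-c4ccccc4)c(=O)oc3c2)nn1`, differs from compound 3 by phenyl in place of hydrogen on an aromatic carbon. Among the measured compounds shown here, no measured step covers this particular change; the only step recorded, from compound 1 to compound 2, concerns a different exchange and was within the scatter. Compounds 1 and 2, which do carry a phenyl-containing group on the shared core, show values that sit within the scatter of compound 3. On these numbers compound 4 is expected to show a step of a number 0.5 percentage points higher from compound 3 to compound 4 (within the scatter), that is, none beyond the scatter. Compound 4 is therefore estimated to give 41% in this assay, between 33% and 49%.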

Compound 4, a percentage reported as activity, at one concentration (the size of the read-out at that concentration, not a potency): 38.6%
The estimate for compound 4 lay 2.4 percentage points above the measured number; low and high end bracket the measured number.
By their numbers in this assay, from the lowest: compounds 4, 3, 2 and 1 (each within the scatter of the next).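

In this assay, among the compounds shown here, the exchange of hydrogen for phenyl on the aromatic carbon two atoms from the ring oxygen gives a number 1.9 percentage points lower from compound 3 to compound 4 (within the scatter), and this is the first direct reading at this position, since the only earlier step changed methoxy to chloro on an aromatic carbon with a phenyl-containing group already present on both compounds. Adding a six-membered aromatic ring of carbon only at this carbon therefore leaves the read-out unchanged within the scatter for this pair, although one pair tested at one concentration gives no measure of potency and supports no rule for other compounds.

The compounds shown leave open whether an amine or a carboxylic acid at this same position, in place of phenyl, would move the number beyond the scatter. They also leave open whether a longer chain in the ether link would do so, with or without the phenyl present. No supporting measurement is available to explain the result for this pair.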